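The source may hold more compounds than are shown below. What is called first, only, known or untested is meant among the compounds shown, and "the series" means these compounds.

In a functional assay on MDA-MB-231 cells (Homo sapiens) for inhibition, read by sulforhodamine B assay (a higher number here means a weaker inhibitor, a lower number a stronger inhibitor), compound 1, `COC(=O)CC/C(C)=C/Cc1c(OC)c(C)c2c(c1OCC#CCN1CCN(c3ccccc3F)CC1)C(=O)OC2`, gives > 50000 nM, which is a limit of the assay and not a number. Compound 2, `COC(=O)CC/C(C)=C/Cc1c(OC)c(C)c2c(c1OCC#CCN1CCN(Cc3ccc(Cl)cc3)CC1)C(=O)OC2`, gives > 50000 nM, again a limit. Compound 3, `COC(=O)CC/C(C)=C/Cc1c(OC)c(C)c2c(c1OCC#CCN1CCN(c3ccccc3OC)CC1)C(=O)OC2`, gives > 50000 nM, also a limit, so its place in the set can only be told as a limit. Compound 3 shares that place with both of the others, as the record shows: the limit of > 50000 nM in this assay, at which 3 of the 3 values shown sit.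

Compound 4, `COC(=O)CC/C(C)=C/Cc1c(OC)c(C)c2c(c1OCC#CCN1CCN(C(=O)C3COc4ccccc4O3)CC1)C(=O)OC2`, keeps the shared core and changes the group on the amine nitrogen in a ring: (2,3-dihydro-1,4-benzodioxin-2-yl)carbonyl in place of 2-methoxyphenyl on an amine nitrogen in a ring. In words, (2,3-dihydro-1,4-benzodioxin-2-yl)carbonyl comes in place of 2-methoxyphenyl.

Among the compounds with values here, three measured steps bear on this change: a step that the two limits leave unreadable from compound 1 to compound 2, a step that the two limits leave unreadable from compound 1 to compound 3 and a step that the two limits leave unreadable from compound 2 to compound 3. None of them has a readable size, so they offer no measured size or direction for the new group. In this assay, within the data shown here, no step of known size is therefore expected, and compound 4 is expected to stay near the same limit because of the limit of > 50000 nM in this assay, at which 3 of the 3 values shown sit. The estimated change is a number no higher from compound 3 to compound 4 (the limit leaves the size open). Compound 4 is estimated at 50000 nM, with an expected range from 15000 nM to 100000 nM.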

Compound 4, half-maximal inhibitory concentration: > 50000 nM
Compound 4 gave a limit, no number; the forecaster's own chance of this, stated with the estimate: 80%; the middle value lies on the limit itself.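

In this assay compound 4 gives > 50000 nM, a limit and not a number. No step from compound 1, compound 2 or compound 3 to compound 4 can be read, because all four share one limit: the limit of > 50000 nM in this assay, at which 4 of the 4 values shown sit.

The compounds shown leave open whether any group on the amine nitrogen in a ring gives a measurable value in this assay.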